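The source may hold more compounds than are shown below. What is called first, only, known or untested is meant among the compounds shown, and "the series" means these compounds.

Measured in an ADME assay on microsomes from liver (Homo sapiens) for metabolic stability, read by LC-MS, tested at 1 uM; on this read-out higher numbers stand for fast clearance and lower numbers for slow clearance:

- compound 1 `NCCOCCOc1ccc([C@H]2CC[C@]3(CC2)OOC2(O3)C3CC4CC(C3)CC2C4)cc1`: < 7 mL.min-1.g-1
- compound 2 `c1cc([C@H]2CC[C@]3(CC2)OOC2(O3)C3CC4CC(C3)CC2C4)ccc1OCCOC1CCNCC1`: < 7 mL.min-1.g-1
- compound 3 `c1cc([C@H]2CC[C@]3(CC2)OOC2(O3)C3CC4CC(C3)CC2C4)ccc1OCC1CCNCC1`: < 7 mL.min-1.g-1

Each of these three entries is a limit and not a number. The whole set sits together: the limit of < 7 mL.min-1.g-1 in this assay, at which 3 of the 3 values shown sit. Compound 3 therefore has no exact place on the scale, and its entry of < 7 mL.min-1.g-1 is a limit.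

Compound 4 `O[C@H]1CC[C@H](NCCCOc2ccc([C@H]3CC[C@]4(CC3)OOC3(O4)C4CC5CC(C4)CC3C5)cc2)CC1` differs from compound 3 as follows: 2-((4-hydroxycyclohexyl)amino)ethyl in place of piperidin-4-yl on a saturated chain carbon bound to an oxygen on an aromatic ring. In words, 2-((4-hydroxycyclohexyl)amino)ethyl comes in place of piperidin-4-yl, on a saturated chain carbon bound to an oxygen on an aromatic ring.

Three measured steps change the group at this end of the molecule: a step that the two limits leave unreadable from compound 1 to compound 2, a step that the two limits leave unreadable from compound 1 to compound 3 and a step that the two limits leave unreadable from compound 2 to compound 3. None of them has a readable size or direction, and none of them brings in the 4-hydroxycyclohexyl group. The expectation thus rests on compound 3 with < 7 mL.min-1.g-1, a limit, and the measured steps speak for neither a rise nor a fall.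

No change beyond the scatter is expected, and the estimate is a number no lower from compound 3 to compound 4 (the limit leaves the size open). Compound 4 is expected at 7 mL.min-1.g-1, with an estimated range of 5 mL.min-1.g-1 to 20 mL.min-1.g-1.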

Compound 4, intrinsic clearance in microsomes: < 7 mL.min-1.g-1
Compound 4 gave a limit, no number; the forecaster's own chance of this, stated with the estimate: 60%; the middle value lies on the limit itself.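

In this assay, no new step can be read: the steps from compound 1, compound 2 and compound 3 to compound 4 join limits only, and neither their size nor their direction is known. All the entries sit together: the limit of < 7 mL.min-1.g-1 in this assay, at which 4 of the 4 values shown sit.

The compounds shown leave open where each of them stands on the scale and whether changing the group at this end of the molecule alters clearance at all.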